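Butyl disulfide in place of an aryl disulfide on a nucleoside

A few compounds are considered here, and "the series" means these few. Any claim that something is new, unique, unknown or untested is made for them only; others in the source may bear on it.

The series comprises disulfide-bearing nucleosides tested in a functional assay on MOLT-4 cells (Homo sapiens) for cytotoxicity; on this read-out higher numbers stand for weaker inhibition and lower numbers for stronger inhibition. Compound 1 `CSS[C@H]1C[C@H](n2ccc(N)nc2=O)O[C@@H]1CO` gives 149000 nM. Compound 2 `Cc1cn([C@H]2C[C@H](SSc3ccccc3[N+](=O)[O-])[C@@H](CO)O2)c(=O)[nH]c1=O` gives 31000 nM, and compound 3 `Cc1cn([C@H]2C[C@H](SSc3ccc([N+](=O)[O-])cc3)[C@@H](CO)O2)c(=O)[nH]c1=O` gives 29000 nM. Among the compounds with values here, on these numbers compound 2 stands second highest of the three, closest to compound 3 and furthest from compound 1; the only single-point step, a 1.1-fold lower number from compound 2 to compound 3 (0.03 log units; within the scatter), shows that moving the nitro group around the ring changes nothing that can be trusted.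

Compound 4 `CCCCSS[C@H]1C[C@H](n2cc(C)c(=O)[nH]c2=O)O[C@@H]1CO` differs from compound 2 in one place: butyl in place of 2-nitrophenyl on a sulfur. Within the data shown here, no measured step describes an aryl-to-alkyl exchange on that sulfur. Compound 1, which carries a short alkyl group on its disulfide but also a different base, shows a higher number than compound 2 and compound 3, so a move toward weaker inhibition is the more likely outcome. The weight of this comparison is limited, since compound 1 also differs from compound 2 in its base. The step from compound 2 to compound 4 is therefore expected to be a 1.9-fold higher number from compound 2 to compound 4 (0.29 log units; within the scatter). Compound 4 is estimated to give 60000 nM, within a range from 20000 nM to 200000 nM.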

Compound 4, half-maximal inhibitory concentration: 28000 nM
Compound 4: the middle estimate sits 2.1-fold (0.33 log units) above what was measured, and the stated range covers the measured number.
By their numbers in this assay, from the lowest: compounds 4, 3 and 2 (each within the scatter of the next); then compound 1.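

In this assay, replacing the aryl group on this sulfur with butyl gives a 1.1-fold lower number from compound 2 to compound 4 (0.04 log units; within the scatter) and a 1.0-fold lower number from compound 3 to compound 4 (0.02 log units; within the scatter). Within the data shown here, the earlier step showed only that the nitro group could occupy either of two ring positions without a change that can be trusted, whereas these steps show the same for removing both the aromatic ring and the nitro group, leaving a plain butyl on the disulfide. Nothing available explains why these numbers stay so close.

As far as these compounds go, it remains open whether this insensitivity extends to a longer chain such as octyl, or to butyl carrying an amine or a carboxylic acid at its end. From the compounds shown here alone, it is also open whether butyl on this sulfur would behave the same way with the base of compound 1.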